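A few compounds are considered here, and "the series" means these few. Any claim that something is new, unique, unknown or untested is made for them only; others in the source may bear on it.

Going by the values given here, three related compounds have numbers so far in a functional assay on MDA-MB-468 cells (Homo sapiens) for cytotoxicity, read by resazurin assay, with a stated time of 72 h (on this read-out lower numbers stand for stronger inhibition and higher numbers for weaker inhibition), and they can be compared directly. Compound 1 `O=C(O)CCSC(=S)NCc1cccnc1` gives 9320 nM here, compound 2 `O=S(=O)(O)CCCSC(=S)NCc1cccnc1` gives 11100 nM and compound 3 `Fc1ccccc1-c1nnc(CCSC(=S)NCc2cccnc2)o1` gives 3420 nM as the lowest of the three numbers, with both gaps beyond the usual scatter. Compound 4 `S=C(NCc1cccnc1)SCCc1nnc(-c2cccs2)o1` is still unmeasured. It differs from compound 3 in one place (thiophen-2-yl in place of 2-fluorophenyl on an aromatic carbon), with thiophen-2-yl in place of 2-fluorophenyl on an aromatic carbon. Among the compounds with values here, the only measured single-place step is a 1.2-fold higher number from compound 1 to compound 2 (0.08 log units; within the scatter) and it swaps carboxy for sulfomethyl, a different change at a different place. Within the data shown here, no measured step therefore speaks directly to this swap, and the data suggest no direction for it. The best anchor is compound 3 at 3420 nM and no shift beyond the scatter is expected. The estimated change (a 1.1-fold higher number from compound 3 to compound 4 (0.05 log units; within the scatter)) is accordingly small. Compound 4 is estimated at 3800 nM with an expected range from 1600 nM to 8500 nM in this measurement.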

Compound 4, half-maximal inhibitory concentration: 3410 nM
Beside the measured number, compound 4's estimate is 1.1-fold (0.05 log units) above it, and the stated range covers the measured number.
By their numbers in this assay, from the lowest: compounds 4 and 3 (each within the scatter of the next); then compounds 1 and 2 (each within the scatter of the next).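

In this assay putting thiophen-2-yl in place of 2-fluorophenyl gives a 1.0-fold lower number from compound 3 to compound 4 (0.00 log units; within the scatter) and is the only step shown at this aromatic carbon. The position thus takes a five-membered aromatic ring with 5 heavy atoms, including a sulfur, in place of a six-membered aromatic ring of carbon only with 7 heavy atoms, and the read-out does not separate the two compounds. Nothing measured on these groups is available to explain this match.

The compounds shown leave open how an amine, a carboxylic acid or a plain methyl on this aromatic carbon would compare with these two aromatic rings. They also leave open whether thiophen-3-yl, or a phenyl ring without fluorine, would give a similar number.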